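The source may hold more compounds than are shown below. What is called first, only, known or untested is meant among the compounds shown, and "the series" means these compounds.

Measured so far in a functional assay on SW1573 cells (Homo sapiens) for antiproliferative activity, read by sulforhodamine B assay, with a stated time of 48 h (on this read-out higher numbers stand for weaker inhibition of growth and lower numbers for stronger inhibition of growth), are two compounds.

- compound 1 `CCCCCC(C#CC(=O)OC)O/C=C/C(=O)OC` gives 1700 nM
- compound 2 `CCC(C)C(C#CC(=O)OC)O/C=C/C(=O)OC` gives 910 nM

Compound 2 lies within the usual scatter of compound 1, so these two numbers cannot be ranked. The next compound is compound 3 `COC(=O)C#CC(O/C=C/C(=O)OC)C(C)C`, which differs from compound 2 by hydrogen in place of methyl on a saturated chain carbon, three bonds along the chain from an oxygen on an unsaturated carbon and a triple-bonded carbon in one group. Sec-butyl becomes isopropyl, with hydrogen in place of methyl on a saturated chain carbon, three bonds along the chain from an oxygen on an unsaturated carbon and a triple-bonded carbon. Among the measured compounds shown here, the one measured step that bears on this is a 1.9-fold lower number from compound 1 to compound 2 (0.27 log units; within the scatter) for sec-butyl in place of pentyl, also a change of this alkyl group. On that single step, no change beyond the scatter is expected in this assay in either direction. The expected step is a 1.0-fold lower number from compound 2 to compound 3 (0.00 log units; within the scatter) and no more than that. For compound 3 the estimated value is 900 nM (expected range 400 nM to 2000 nM).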

Compound 3, concentration for 50% growth inhibition: 750 nM
Estimate against measurement, compound 3: 1.2-fold (0.08 log units) above, within the range that was stated.
By their numbers in this assay, from the lowest: compounds 3, 2 and 1 (each within the scatter of the next, the first and the last beyond it).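

In this assay, hydrogen in place of methyl, which turns sec-butyl into isopropyl, gives a 1.2-fold lower number from compound 2 to compound 3 (0.08 log units; within the scatter) and so has no readable effect at this position. Among the compounds shown here, replacing pentyl with isopropyl on the same carbon gives a 2.3-fold lower number from compound 1 to compound 3 (0.36 log units; beyond the scatter) as the first step here beyond the scatter, showing that the alkyl group at this position can shift growth inhibition, though only modestly. No evidence is available to explain this shift.

The compounds shown leave open whether the trend from pentyl to isopropyl would extend to other groups at this carbon, such as a cyclohexyl ring or a chain carrying an amine. They also do not show how much the two methyl ester groups or the triple bond of the shared core contribute to the activity.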